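Adding a Methyl to the Benzyl Group of Compound 2

The source may hold more compounds than are shown below. What is called first, only, known or untested is meant among the compounds shown, and "the series" means these compounds.

In an assay on isolated protein for inhibition of protein deacetylase HDAC6 (Homo sapiens), read by fluorescence, with stated times of 10 min and 2 h (a higher number here means a weaker inhibitor, a lower number a stronger inhibitor), compound 1 `CN1CC(=O)N(Cc2ccc(C(=O)NO)cc2)C1=O` gives 119 nM.
In this assay compound 2 `O=C(NO)c1ccc(CN2C(=O)CN(Cc3ccccc3)C2=O)cc1` gives 12.5 nM.

Compound 2 has the lower of the two numbers; the nearest is compound 1, and the step of a 9.5-fold lower number from compound 1 to compound 2 (0.98 log units; beyond the scatter) came from putting phenyl in place of hydrogen on a saturated chain carbon bound to an amide-type nitrogen in a ring. Compound 3 `Cc1ccc(CN2CC(=O)N(Cc3ccc(C(=O)NO)cc3)C2=O)cc1` differs from compound 2 by methyl in place of hydrogen on an aromatic carbon, para to a large group, so that benzyl becomes 4-methylbenzyl. Among the measured compounds shown here, no measured step changes a substituent on this ring; the single measured step installed the ring itself and says nothing about a methyl on it. With nothing that bears directly on the change, no step beyond the scatter is expected. Compound 3 is therefore estimated to give 11 nM, within 4 nM to 30 nM. This means an expected step of a 1.1-fold lower number from compound 2 to compound 3 (0.06 log units; within the scatter), staying within the scatter.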

Compound 3, half-maximal inhibitory concentration: 17.6 nM
Beside the measured number, compound 3's estimate is 1.6-fold (0.20 log units) below it, within the range that was stated.
By their numbers in this assay, from the lowest: compounds 2 and 3 (each within the scatter of the next); then compound 1.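

In this assay, methyl in place of hydrogen on an aromatic carbon, para to a large group, gives a small step (a 1.4-fold higher number from compound 2 to compound 3 (0.15 log units; within the scatter)), so benzyl and 4-methylbenzyl cannot be told apart here. Among the compounds shown here, this is the first information about a substituent on this ring, and it shows that this one added carbon leaves the number within the scatter. The advantage over the small methyl of compound 1 also remains with 4-methylphenyl in place (a 6.8-fold lower number from compound 1 to compound 3 (0.83 log units; beyond the scatter)), although no measurement available here explains either step.

Going by these compounds, a single methyl at one place says little about other groups, so the effect of a methoxy, an amine or a carboxylic acid at this position remains open. The effect of a methyl elsewhere on the ring is equally unknown.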